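Clearance notes: changing the amine-nitrogen group

The source may hold more compounds than are shown below. What is called first, only, known or untested is meant among the compounds shown, and "the series" means these compounds.

Measured so far in an ADME assay on the whole organism (Rattus norvegicus, strain Sprague-Dawley) for pharmacokinetics, read by LC-MS, at a dose of 1 mg/kg by the intravenous route; on this read-out higher numbers stand for fast clearance and lower numbers for slow clearance:
- compound 1 `Cc1cccc(Cl)c1CN1CCc2cc(-c3c(C)nc(C)c([C@H](OC(C)(C)C)C(=O)O)c3N3CCC(C)(C)CC3)ccc2C1`: 3.5 mL/min/kg
- compound 2 `Cc1nc(C)c([C@H](OC(C)(C)C)C(=O)O)c(N2CCC(C)(C)CC2)c1-c1ccc2c(c1)CCN(c1ncnc3c1cnn3C)C2`: 3.6 mL/min/kg

Among the measured compounds shown here, only two numbers exist, and compound 2 stands within the scatter of compound 1, so neither can be ranked against the other. The next compound to be read is compound 3 `Cc1nc(C)c([C@H](OC(C)(C)C)C(=O)O)c(N2CCC(C)(C)CC2)c1-c1ccc2c(c1)CCN(c1nc3cnccc3s1)C2`. It keeps the core of compound 2, and the change is a group of 9 heavy atoms (6 carbon, 2 nitrogen, 1 sulfur; one five-membered aromatic ring with 2 hetero atoms, one six-membered aromatic ring with 1 hetero atom) in place of a group of 10 heavy atoms (6 carbon, 4 nitrogen; one five-membered aromatic ring with 2 hetero atoms, one six-membered aromatic ring with 2 hetero atoms), on an amine nitrogen in a ring. This falls on an amine nitrogen in a ring.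

For the measured compounds named here, one measured step bears on this place: a 1.0-fold higher number from compound 1 to compound 2 (0.01 log units; within the scatter). That exchange of one group for another on the same nitrogen left this assay within the scatter. Going by the values given here, no measured compound carries a group with sulfur here, so this single step is thin support. No step beyond the scatter is expected, and no direction is favoured. The expected step is a 1.1-fold higher number from compound 2 to compound 3 (0.05 log units; within the scatter). For compound 3 the estimated value is 4 mL/min/kg, with an expected range of 1.8 mL/min/kg to 9 mL/min/kg.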

Compound 3, clearance: 14.8 mL/min/kg
For compound 3 the middle estimate is 3.7-fold (0.57 log units) below the measured one; the whole stated range lies below it.
By their numbers in this assay, from the lowest: compounds 1 and 2 (each within the scatter of the next); then compound 3.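

In this assay, the amine nitrogen in a ring now proves to be a place where exchanging one group for another can move the number beyond the scatter: the group of 9 heavy atoms carrying sulfur gives a 4.1-fold higher number from compound 2 to compound 3 (0.61 log units; beyond the scatter) and a 4.2-fold higher number from compound 1 to compound 3 (0.63 log units; beyond the scatter). Among the compounds shown here, the only earlier exchange at this nitrogen, a 1.0-fold higher number from compound 1 to compound 2 (0.01 log units; within the scatter), stayed within the scatter, so the flat picture from that pair holds for those two groups only and does not extend to every group at this place. Nothing at hand accounts for the rise in clearance.

Between compound 2 and compound 3, the five-membered aromatic ring gains sulfur while the six-membered aromatic ring goes from 2 hetero atoms to 1, so the compounds shown do not separate these two changes. Going by these compounds, it also remains open whether a group with the same two rings but oxygen in place of sulfur would read with compound 1 and compound 2 or with compound 3.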